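The source may hold more compounds than are shown below. What is called first, only, known or untested is meant among the compounds shown, and "the series" means these compounds.

Of the compounds shown here, three built on one shared core have been measured in an assay on isolated protein for displacement of a labelled ligand from 5-hydroxytryptamine receptor 6 (Homo sapiens); on this read-out higher numbers stand for weaker inhibition and lower numbers for stronger inhibition. Compound 1 `CNCC1CCCc2cc(S(=O)(=O)c3ccccc3)ccc21` gives 0.316 nM; compound 2 `NC[C@@H]1CCCc2cc(S(=O)(=O)c3cccc(O)c3)ccc21` gives 0.251 nM; compound 3 `COc1cccc(S(=O)(=O)c2ccc3c(c2)CCC[C@H]3CN)c1` gives 0.398 nM. Compound 2 shows the lowest of these three numbers, but its gaps to compound 1 and to compound 3 both lie within the scatter, as the step of a 1.6-fold higher number from compound 2 to compound 3 (0.20 log units; within the scatter) illustrates. Compound 4 `NC[C@@H]1CCCc2cc(S(=O)(=O)c3cc[nH]c3)ccc21` differs from compound 2 by 1H-pyrrol-3-yl in place of 3-hydroxyphenyl on a sulfonyl sulfur. Going by the values given here, no measured step exchanges one aromatic ring for another, so none bears directly on this change. Compound 4 is therefore expected to give roughly 0.6 nM, within a range from 0.15 nM to 2.5 nM. This estimate implies a step of a 2.4-fold higher number from compound 2 to compound 4 (0.38 log units; beyond the scatter), expected to be modest and near the edge of the scatter.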

Compound 4, inhibition constant: 0.316 nM
Beside the measured number, compound 4's estimate is 1.9-fold (0.28 log units) above it, and the stated range covers the measured number.
By their numbers in this assay, from the lowest: compounds 2, 1, 4 and 3 (each within the scatter of the next).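

On a sulfonyl sulfur, 1H-pyrrol-3-yl in place of 3-hydroxyphenyl gives a 1.3-fold higher number from compound 2 to compound 4 (0.10 log units; within the scatter) in this assay and so stays level with compound 2. The earlier step altered only a group on an oxygen, whereas here the aromatic ring itself changes, from six-membered of carbon only to five-membered with 1 hetero atom, without a shift beyond the scatter. No supporting data explain why the number holds across this exchange.

Open, from the compounds shown here alone, is whether a pyridin-3-yl or thiophen-3-yl ring on the sulfonyl sulfur would behave alike. Also open, going by these compounds, is how a carboxylic acid on that ring would fare.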